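The source may hold more compounds than are shown below. What is called first, only, known or untested is meant among the compounds shown, and "the series" means these compounds.

Measured so far in a functional assay on HCT-116 cells (Homo sapiens) for inhibition, read by MTT assay, with a stated time of 48 h; a lower number here means a stronger inhibitor, a higher number a weaker inhibitor:
compound 1 `C/C=C/C(=O)N(Cc1cccc(O)c1)c1cc(OC)c(OC)c(OC)c1`, 6700 nM;
compound 2 `CCC(=O)N(Cc1ccc(OC)c(O)c1)c1cc(OC)c(OC)c(OC)c1`, 61 nM;
compound 3 `COC(=O)c1cc(CNc2cc(OC)c(OC)c(OC)c2)ccc1OC`, 38100 nM.

Compound 2 gives the lowest number of the three in this assay; the nearest is compound 1, and compound 3 lies furthest away, both beyond the scatter. The open question is compound 4 `COc1ccc(CN(C(=O)C[Se]C#N)c2cc(OC)c(OC)c(OC)c2)cc1O`, not yet run in this assay. It differs from compound 2 in one place: a group of 3 heavy atoms (1 carbon, 1 nitrogen, 1 selenium; no ring) in place of one carbon atom, on a saturated chain carbon bound to a carbonyl carbon. The shared core, the amide and the ring bearing the hydroxyl group are kept from compound 2. Within the data shown here, no measured pair isolates such a change, so the expected step is taken as small, at most a modest rise beyond the scatter, with a loss more likely than a gain. Compound 4 is estimated at 150 nM, range 30 nM to 800 nM, an expected step of a 2.5-fold higher number from compound 2 to compound 4 (0.39 log units; beyond the scatter).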

Compound 4, half-maximal inhibitory concentration: 310 nM
Compound 4: middle estimate off by 2.1-fold (0.32 log units), on the low side; measured number inside the range.
By their numbers in this assay, from the lowest: compound 2; then compound 4; then compound 1; then compound 3.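

In this assay, the group of 3 heavy atoms (1 carbon, 1 nitrogen, 1 selenium) entering in place of methyl, on a saturated chain carbon bound to a carbonyl carbon, gives a 5.1-fold higher number from compound 2 to compound 4 (0.71 log units; beyond the scatter). This position therefore accepts a larger group with a triple bond at a modest cost, not a collapse of activity. Nothing available accounts for the size of this step. Open, as far as these compounds go, is whether the selenium or the nitrile sets the step, since the entering group changes both together. From the compounds shown here alone, an amine or a longer chain at this position also remains open.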